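A few compounds are considered here, and "the series" means these few. Any claim that something is new, unique, unknown or untested is made for them only; others in the source may bear on it.

Measured so far in a functional assay on MDA-MB-231 cells (Homo sapiens) for cytotoxicity, read by MTT assay, with a stated time of 72 h; on this read-out higher numbers stand for weaker inhibition and lower numbers for stronger inhibition:
compound 1, `COc1cc2c(Oc3ccc(NC(=O)N/N=C/c4ccc(C(F)(F)F)cc4)cc3F)ccnc2cc1OCCCN1CCCCC1`, where compound 1 gives 1100 nM
compound 2, `COc1cc2c(Oc3ccc(NC(=O)N/N=C/c4ccc(Cl)cc4Cl)cc3F)ccnc2cc1OCCCN1CCCCC1`, where compound 2 gives 750 nM
compound 3, `COc1cc2c(Oc3ccc(NC(=O)N/N=C/c4ccc(C(F)(F)F)cc4)cc3F)ccnc2cc1OCCCN1CCC(C)CC1`, where compound 3 gives 1300 nM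

Compound 4, `COc1cc2c(Oc3ccc(NC(=O)N/N=C/c4ccc(Cl)cc4Cl)cc3F)ccnc2cc1OCCCN1CCC(C)CC1`, has not yet been measured in this assay.

Compound 2 differs from compound 1 by 2,4-dichlorophenyl in place of 4-(trifluoromethyl)phenyl on a carbon with a double bond to nitrogen. That change made a 1.5-fold lower number from compound 1 to compound 2 (0.17 log units; within the scatter). The cores of compound 1 and compound 3 differ by methyl in place of hydrogen on a saturated ring carbon, a change that made a 1.2-fold higher number from compound 1 to compound 3 (0.07 log units; within the scatter). Compound 4 differs from compound 3 by 2,4-dichlorophenyl in place of 4-(trifluoromethyl)phenyl on a carbon with a double bond to nitrogen. The place of this change is described in the same words as for the change from compound 1 to compound 2, so it is the same change, now made on the core of compound 3; among the compounds shown it occurs twice in all, and only one instance has a measured outcome. The step from compound 3 to compound 4 is expected to be a 1.5-fold lower number from compound 3 to compound 4 (0.17 log units; within the scatter), close in size to the earlier one, because a 1.5-fold lower number from compound 1 to compound 2 (0.17 log units; within the scatter) stayed within the scatter and the change is the same. Compound 4 is therefore estimated at 870 nM, with a likely range from 400 nM to 1900 nM.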

Compound 4, half-maximal inhibitory concentration: 910 nM
Beside the measured number, compound 4's estimate is 1.0-fold (0.02 log units) below it; measured number inside the range.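

In this assay, 2,4-dichlorophenyl in place of 4-(trifluoromethyl)phenyl gives a 1.4-fold lower number from compound 3 to compound 4 (0.15 log units; within the scatter), and this matches the earlier step with the same change: the same change on two cores in this assay, a 1.5-fold lower number (0.17 log units; within the scatter) from compound 1 to compound 2 and a 1.4-fold lower number (0.15 log units; within the scatter) from compound 3 to compound 4, 1.0-fold (0.01 log units) apart, within the scatter of two such steps. Methyl in place of hydrogen on a saturated ring carbon gives a 1.2-fold higher number from compound 2 to compound 4 (0.08 log units; within the scatter), and it too matches its earlier step: the same change on two cores in this assay, a 1.2-fold higher number (0.07 log units; within the scatter) from compound 1 to compound 3 and a 1.2-fold higher number (0.08 log units; within the scatter) from compound 2 to compound 4, 1.0-fold (0.01 log units) apart, within the scatter of two such steps. Across these four compounds, each change reads the same on both cores, but every step lies within the scatter, so this shows only that neither change moved the number measurably here, not that a larger step would carry over or that the same would hold on other cores.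

The compounds shown leave open whether a nitrile or a carboxylic acid in place of the 2,4-dichlorophenyl, or an ethyl in place of the methyl on the saturated ring carbon, would give a step beyond the scatter. They also leave open whether such a step would stay the same from one core to another.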